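The source may report more compounds than this note shows. Statements on the series, on what has been measured and on what is new or still open speak of the compounds shown alone.

The study concerns four compounds built on a shared core, three of which have been measured in an ADME assay on HEK293 cells (Homo sapiens) for inhibition, read by MTT assay, with a stated time of 2 days; a higher number here means a weaker inhibitor, a lower number a stronger inhibitor. Compound 1 `Nc1ccccc1/C=C/c1ccc(O)cc1` gives 7 ug/mL. Compound 2 `COc1ccc(/C=C/c2ccccc2O)cc1` gives 21 ug/mL in this assay, and compound 3 `Nc1ccc(/C=C/c2ccccc2O)cc1` gives 21.4 ug/mL. Compound 1 therefore holds the lowest of the three numbers, and its gap to each of the others is beyond the scatter. Compound 1 and compound 3 have the same atoms joined differently; the difference between the two cores is not broken down here.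

Compound 2 differs from compound 3 by methoxy in place of amino on an aromatic carbon, and the step of a 1.0-fold lower number from compound 3 to compound 2 (0.01 log units; within the scatter) is within the scatter. The unmeasured compound 4 `COc1ccccc1/C=C/c1ccc(O)cc1` stands to compound 1 as compound 2 stands to compound 3: the change is methoxy in place of amino on an aromatic carbon. The two place descriptions differ in one word, one reading para to a group of 9 heavy atoms and the other ortho to a group of 9 heavy atoms, so the change is the same kind of change rather than the same change. On this single precedent the step in this assay is expected to be small, a 1.1-fold higher number from compound 1 to compound 4 (0.06 log units; within the scatter). That expectation rests on the earlier step of a 1.0-fold lower number from compound 3 to compound 2 (0.01 log units; within the scatter), which moved the number hardly at all. Compound 4 is accordingly estimated at 8 ug/mL. A range from 3.5 ug/mL to 18 ug/mL is expected for compound 4, wide enough to allow for the different place of the change.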

Compound 4, half-maximal inhibitory concentration: 41 ug/mL
Estimate against measurement, compound 4: 5.1-fold (0.71 log units) below; the whole stated range lies below it.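

In this assay, putting methoxy in place of amino on an aromatic carbon of the core of compound 1, ortho to a group of 9 heavy atoms, gave a 5.9-fold higher number from compound 1 to compound 4 (0.77 log units; beyond the scatter), so here the change weakens inhibition beyond the scatter rather than leaving the number where it was. The same kind of change therefore did not carry over from one core to the other with the same size: the same change on two cores in this assay, a 1.0-fold lower number (0.01 log units; within the scatter) from compound 3 to compound 2 and a 5.9-fold higher number (0.77 log units; beyond the scatter) from compound 1 to compound 4, 6.0-fold (0.78 log units) apart, beyond the scatter of two such steps. What this does not show is which difference between the two pairs matters, as the place of the change and the rest of the core differ together, and two pairs give no rule for how the change would behave on any further core in the series.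

The compounds shown leave open whether the gap follows the place of the change or the rest of the core, a question that would need the same change at the same place on both cores. They also leave open how other groups at this position, such as a nitrile, a carboxylic acid or a longer chain like ethoxy, would compare with amino and methoxy on either core.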